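This account rests on a few compounds, and the source may have more. Where it says the series, first, only, none or still open, it means among the compounds named here.

In a functional assay on HT-29 cells (Homo sapiens) for antiproliferative activity, read by sulforhodamine B assay, with a stated time of 48 h (on this read-out lower numbers stand for stronger inhibition and higher numbers for weaker inhibition), the measured compounds stand as follows:

compound 2 `CC(=O)Nc1ccc(S(=O)(=O)Oc2ccccc2C(C)C)cc1` gives 23000 nM
compound 3 `CC(=O)Nc1ccc(S(=O)(=O)Oc2ccccc2I)cc1` gives 23000 nM
compound 1 `CCCCCC(=O)Nc1cccc(S(=O)(=O)Oc2ccccc2C(C)C)c1` gives 19000 nM

Compound 2 and compound 3 are level at the digits shown and together hold the highest numbers of the three. Compound 1, which differs from compound 2 in more than one place, gives a number only slightly lower, and that gap lies within the scatter. Compound 4 `CC(C)c1ccccc1OS(=O)(=O)c1ccc(NC(=O)C(C)(C)C)cc1` differs from compound 2 in one place: tert-butyl in place of methyl on a carbonyl carbon. Among the measured compounds shown here, the only single-change step measured from compound 2 is no change at the digits printed from compound 2 to compound 3 (within the scatter), which alters a group on an aromatic carbon, not the group on the carbonyl carbon that changes here, so it bears on the new step only as a sign that this series has so far tolerated a swap of substituent without moving the read-out. For the measured compounds named here, compound 1 offers no single-change step, and its value and that of compound 2 show no difference beyond the scatter. On this evidence the step to compound 4 is expected to produce no change in this assay beyond the scatter, a 1.0-fold lower number from compound 2 to compound 4 (0.02 log units; within the scatter). Compound 4 is therefore estimated at 22000 nM, within a range of 9000 nM to 55000 nM.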

Compound 4, half-maximal inhibitory concentration: 15000 nM
Estimate against measurement, compound 4: 1.5-fold (0.17 log units) above, within the range that was stated.
By their numbers in this assay, from the lowest: compounds 4, 1, 2 and 3 (each within the scatter of the next).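

In this assay, the carbonyl carbon bearing the amide-type nitrogen now has a measured step of its own: tert-butyl in place of methyl, taking the group there from 1 heavy atom to 4, gives a 1.5-fold lower number from compound 2 to compound 4 (0.19 log units; within the scatter) and so does not move the read-out beyond the scatter. Among the compounds shown here, the earlier compounds offered a single-change step only on an aromatic carbon, so this is the first reading that a change at this carbonyl carbon, here a substantial gain in carbon atoms, also stays within the scatter. No evidence is available that would explain this result or assign any property to the tert-butyl group.

The compounds shown leave open whether this carbonyl carbon would stay as undemanding with something other than an alkyl group on it, such as an amine, a phenyl ring or a carboxylic acid, any of which might or might not carry the number beyond the scatter. They also leave open whether tert-butyl at this place would read the same with iodo in place of isopropyl on the aromatic carbon.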